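This account rests on a few compounds, and the source may have more. Where it says the series, first, only, none or still open, it means among the compounds named here.

Among the measured compounds shown here, in a functional assay on CAL-27 cells (Homo sapiens) for cytotoxicity, read by MTT assay, with a stated time of 72 h (on this read-out higher numbers stand for weaker inhibition and lower numbers for stronger inhibition), two related compounds have numbers so far. Compound 1 (`Cc1cc(C)cc(C(=O)N(CC(=O)NCc2ccccc2)Cc2ccc(C(=O)Nc3cc(-c4ccccc4)ccc3N)cc2)c1`) gives 8900 nM and compound 2 (`Nc1ccccc1NC(=O)c1ccc(CN(CC(=O)NCc2ccccc2)C(=O)c2cccnc2)cc1`) gives 11200 nM so the two lie within the usual scatter of each other, and compound 2 stands level with compound 1. Compound 3 (`Cc1cc(C)cc(C(=O)N(CC(=O)NCc2ccccc2)Cc2ccc(C(=O)Nc3ccccc3N)cc2)c1`) has not yet been measured. It departs from compound 2 in one place, with 3,5-dimethylphenyl in place of pyridin-3-yl on a carbonyl carbon. For the measured compounds named here, no measured pair shows this change on its own, so the evidence is thin. Compound 1 also bears 3,5-dimethylphenyl on a carbonyl carbon and gives 8900 nM as its number, so only a small shift is expected. The expected move is toward stronger inhibition, an estimated 1.6-fold lower number from compound 2 to compound 3 (0.20 log units; within the scatter) that would probably stay within the scatter. For compound 3 the estimate is 7000 nM with an expected range (2500 nM to 18000 nM) around it.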

Compound 3, half-maximal inhibitory concentration: 1600 nM
Compound 3: the middle estimate sits 4.4-fold (0.64 log units) above what was measured; the measured number lies below the stated range.
By their numbers in this assay, from the lowest: compound 3; then compounds 1 and 2 (each within the scatter of the next).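

In this assay, among the compounds shown here, putting 3,5-dimethylphenyl in place of pyridin-3-yl on a carbonyl carbon gives a 7.0-fold lower number from compound 2 to compound 3 (0.85 log units; beyond the scatter), the first sign that the group at this position can change the result by more than the scatter. Hydrogen in place of phenyl on an aromatic carbon gives a 5.6-fold lower number from compound 1 to compound 3 (0.75 log units; beyond the scatter), so a second place counts too, and 3,5-dimethylphenyl alone does not guarantee the lower number, as compound 1 carries it as well. Nothing available here explains either step.

The compounds shown do not separate the effect of the two methyl groups from that of losing the ring nitrogen, and a plain phenyl on the same carbonyl carbon would help to tell them apart. Going by these compounds, how a methyl group or a fluorine atom would behave in place of that hydrogen also remains open.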